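A Cyclohexyl Ring in Place of an Ethoxymethyl Chain

The source may hold more compounds than are shown below. What is called first, only, known or untested is meant among the compounds shown, and "the series" means these compounds.

Compound 1 `Cc1noc(CC2OC(=O)c3ccccc32)n1` gives in a functional assay on RAW264.7 cells (Mus musculus) for inhibition, read by Griess assay, with stated times of 1 h and 24 h (on this read-out lower numbers stand for stronger inhibition and higher numbers for weaker inhibition), a value of > 10000 nM, a limit of the assay rather than a number.
Compound 2 `O=C1OC(Cc2nc(Cc3ccccc3)no2)c2ccccc21` gives in this assay a value of > 10000 nM, again a limit and not a number.
Compound 3 `CCOCCOc1ccc(C(O)C2OC(=O)c3c(OC)cc(OC)cc32)cc1` gives in this assay a value of > 10000 nM, which is also a limit and not a number.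

All three measured compounds therefore stand at the same place: none reaches a readable inhibition. Among the compounds with values here, the one pair that differs in a single place, compound 1 and compound 2, yields the step that the two limits leave unreadable from compound 1 to compound 2, which cannot be read because the limit of > 10000 nM in this assay, at which 3 of the 3 values shown sit, holds both of its ends. Compound 3 stands at that same limit, so its position is known only as a bound.

Compound 4 `COc1cc(OC)c2c(c1)C(C(O)c1ccc(OCC3CCCCC3)cc1)OC2=O` is not yet measured. It differs from compound 3 as cyclohexyl in place of ethoxymethyl on a saturated chain carbon bound to an oxygen on an aromatic ring. Within the data shown here, no measured step speaks to this change; the only step available is unreadable, and nothing in the data points toward a gain in inhibition. The expectation for compound 4 is therefore that it, too, sits at or near the limit, and its value in this assay is estimated at 15000 nM, with a range from 4000 nM to 60000 nM. The expected step is a step that the limit leaves unreadable from compound 3 to compound 4.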

Compound 4, half-maximal inhibitory concentration: > 10000 nM
Compound 4: no number, only a limit; the forecaster's own chance of this, stated with the estimate: 70%; the middle value is on the limit's open side.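

In this assay compound 4 gives > 10000 nM, a limit and not a number, so no step can be read between compound 3 and compound 4: the limit of > 10000 nM in this assay, at which 4 of the 4 values shown sit.

The compounds shown leave open whether any change to these structures brings inhibition to a readable value, and which groups would matter for it.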